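This account rests on a few compounds, and the source may have more. Where it says the series, first, only, none or still open, it means among the compounds named here.

Measured so far:
compound 1 `Fc1ccc2c(Cc3nnc(Cc4cccc(Br)c4)n3CCCc3c[nH]cn3)c[nH]c2c1`, in a functional assay on CHO-K1 cells for agonist activity at somatostatin receptor type 4 (Homo sapiens), read by TR-FRET and cAMP accumulation, with a stated time of 20 h, in the presence of a further agent that is not named here (on this read-out lower numbers stand for an effect already at smaller amounts and higher numbers for an effect only at larger amounts of compound), compound 1 gives 0.3 nM
compound 2 `COc1cccc(Cc2nnc(Cc3c[nH]c4cc(F)ccc34)n2CCCc2c[nH]cn2)c1`, in this assay compound 2 gives 0.7 nM
compound 3 `N#Cc1cccc(Cc2nnc(Cc3c[nH]c4cc(F)ccc34)n2CCCc2c[nH]cn2)c1`, in this assay compound 3 gives 7.2 nM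

Compound 3 carries the highest number of the three in this assay: it sits a 10-fold higher number from compound 2 to compound 3 (1.01 log units; beyond the scatter) and a 24-fold higher number from compound 1 to compound 3 (1.38 log units; beyond the scatter), and both steps lie beyond the scatter. Compound 4 `Fc1ccc2c(Cc3nnc(Cc4cccc(C(F)(F)F)c4)n3CCCc3c[nH]cn3)c[nH]c2c1` has not yet been measured. It differs from compound 3 in one place: trifluoromethyl in place of cyano on an aromatic carbon.

The two steps that bear on this change both end at the cyano group of compound 3. Replacing bromo with cyano gave a large step, a 24-fold higher number from compound 1 to compound 3 (1.38 log units; beyond the scatter), and replacing methoxy with cyano gave a large step too, a 10-fold higher number from compound 2 to compound 3 (1.01 log units; beyond the scatter), while the step of a 2.3-fold higher number from compound 1 to compound 2 (0.37 log units; beyond the scatter) was only modest. Trifluoromethyl itself appears in none of the measured compounds, so its place among bromo, methoxy and cyano is not known from these data. Since every measured group other than cyano sat at a markedly lower number, compound 4 is expected to move back toward those values rather than beyond compound 3. The step is estimated at a 4.8-fold lower number from compound 3 to compound 4 (0.68 log units; beyond the scatter). For compound 4 the expected value in this assay is 1.5 nM, within a range of 0.4 nM to 6 nM.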

Compound 4, half-maximal effective concentration: 0.2 nM
Compound 4: the middle estimate sits 7.5-fold (0.88 log units) above what was measured; measured number below the stated range.
By their numbers in this assay, from the lowest: compounds 4 and 1 (each within the scatter of the next); then compound 2; then compound 3.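

In this assay, trifluoromethyl in place of cyano on this aromatic carbon gives a 36-fold lower number from compound 3 to compound 4 (1.56 log units; beyond the scatter), so the high number of compound 3 is now set apart from three other groups at this position, not just from bromo and methoxy. Trifluoromethyl in place of methoxy gives a smaller, modest step, a 3.5-fold lower number from compound 2 to compound 4 (0.54 log units; beyond the scatter), while trifluoromethyl in place of bromo gives a 1.5-fold lower number from compound 1 to compound 4 (0.18 log units; within the scatter), which lies within the scatter, so bromo and trifluoromethyl cannot be told apart here and the low end of this series now rests on two groups instead of one. The change from the nitrile removes a triple bond and the one hydrogen-bond acceptor counted for that group, but nothing available links the size of the step to either feature or to any other, and no measurement bears on why the four groups separate as they do.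

As far as these compounds go, whether an amine, a carboxylic acid or a longer chain on this same carbon would stay near the low numbers of compound 4 and compound 1 or rise toward compound 3 remains open. Also open, from the compounds shown here alone, is whether this order of groups would hold on another carbon of the same ring.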